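Chloro for Methyl on a Fused Core

The source may report more compounds than this note shows. Statements on the series, on what has been measured and on what is new or still open speak of the compounds shown alone.

Measured so far:
compound 1 `Cc1cccc2c1CC/C2=C\C(=O)NC1CC1`: 7%
compound 2 `Cc1cccc2c1CC/C2=C\C(N)=O`: 13%

Of the compounds shown here, two with a shared core have been tested in a functional assay on the whole organism with Rattus norvegicus as the target, at a dose of 20 mg/kg by the oral route; a lower number here means less inhibition, a higher number more inhibition at the dose given (going by the name of the read-out). Compound 1 gives 7%, the smaller of the two numbers shown, while compound 2 gives 13%, a value that sits within the usual scatter of the first. For the measured compounds named here, the only step between measured compounds, a number 6 percentage points higher from compound 1 to compound 2 (within the scatter), exchanges hydrogen for cyclopropyl on an amide-type nitrogen and stays within the scatter.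

Compound 3 `O=C(/C=C1\CCc2c(Cl)cccc21)NC1CC1` has not been measured. It differs from compound 1 by chloro in place of methyl on an aromatic carbon. Going by the values given here, no measured step touches this aromatic carbon, and the one step known concerns the amide-type nitrogen only. With nothing to point in either direction, the step is expected to be a number 3 percentage points higher from compound 1 to compound 3 (within the scatter), none beyond the scatter. Compound 3 is therefore estimated to give 10%, with a range from 0% to 28%.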

Compound 3, a percentage reported as inhibition, in the whole organism at one dose (the size of the read-out at that dose, not a potency): 45%
Beside the measured number, compound 3's estimate is 35 percentage points below it; the measured number lies above the stated range.
By their numbers in this assay, from the lowest: compounds 1 and 2 (each within the scatter of the next); then compound 3.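

In this assay, chloro in place of methyl on an aromatic carbon gives a number 38 percentage points higher from compound 1 to compound 3 (beyond the scatter), which shows that this position, untouched by the earlier step, can move the read-out beyond the scatter. The earlier change on the amide-type nitrogen, a number 6 percentage points higher from compound 1 to compound 2 (within the scatter), gave no such separation, so this is the first single change among the compounds shown that clearly shifts the number. Nothing available accounts for the size of this step.

The compounds shown leave open whether chloro on this aromatic carbon would raise the number in the same way with the hydrogen of compound 2 on the amide-type nitrogen. They also leave open how fluoro, bromo, methoxy or an amine at this carbon would compare with chloro and methyl.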